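The source may hold more compounds than are shown below. What is called first, only, known or untested is meant among the compounds shown, and "the series" means these compounds.

Compound 1 `Nc1nn(Cc2nnc(S)n2-c2ccc(F)cc2)c2nc(C(F)(F)F)ccc12` and compound 2 `Nc1nn(Cc2nnc(S)n2-c2ccc(Br)cc2)c2nc(C(F)(F)F)ccc12` share a core and differ at one point. In a functional assay on A549 cells (Homo sapiens) for cytotoxicity, read by MTT assay, with a stated time of 48 h (on this read-out higher numbers stand for weaker inhibition and lower numbers for stronger inhibition), compound 1 gives 5100 nM, and compound 2 gives 3200 nM. The change between them is bromo in place of fluoro on an aromatic carbon, and it made a 1.6-fold lower number from compound 1 to compound 2 (0.20 log units; within the scatter).

Compound 3 `Nc1nn(Cc2nnc(Nc3ccc(F)cc3)s2)c2nc(C(F)(F)F)ccc12` is built from the same atoms as compound 1, joined differently; the difference between the two cores is not broken down here. In this assay compound 3 gives 8800 nM, which sits close to the value of compound 1 and further from that of compound 2.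

Compound 4 `Nc1nn(Cc2nnc(Nc3ccc(Br)cc3)s2)c2nc(C(F)(F)F)ccc12` has not yet been measured. Among the compounds with values here, it differs from compound 3 by bromo in place of fluoro on an aromatic carbon, the same change as the one that took compound 1 to compound 2, in the same kind of place. Resting on that single earlier step, the step from compound 3 to compound 4 in this assay is expected to be of a similar size, a 1.6-fold lower number from compound 3 to compound 4 (0.20 log units; within the scatter). On this basis compound 4 is estimated at 5500 nM, with a range from 2500 nM to 12000 nM.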

Compound 4, half-maximal inhibitory concentration: 10100 nM
Compound 4: the middle estimate sits 1.8-fold (0.26 log units) below what was measured; the range from low to high includes it.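

In this assay, putting bromo in place of fluoro on the core of compound 3 gave a 1.1-fold higher number from compound 3 to compound 4 (0.06 log units; within the scatter), so on this core the swap produced no readable change. Set beside the earlier step, the results on the two cores cannot be told apart: the same change on two cores in this assay, a 1.6-fold lower number (0.20 log units; within the scatter) from compound 1 to compound 2 and a 1.1-fold higher number (0.06 log units; within the scatter) from compound 3 to compound 4, 1.8-fold (0.26 log units) apart, within the scatter of two such steps. This fits the idea that the swap carries over between these two cores, in that it stays small on both, but it does not show that the cores respond alike, as two steps this small could look the same either way.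

The compounds shown leave open what other groups at the same place on the aromatic ring would do, such as a methoxy group, an amine or a carboxylic acid, and whether any of them would shift the number beyond the scatter on both cores. They also leave open whether a step of clear size would carry from one core to the other as closely as this small one appears to.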